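A few compounds are considered here, and "the series" means these few. Any claim that something is new, unique, unknown or untested is made for them only; others in the source may bear on it.

Among the measured compounds shown here, compound 1 `CN(Cc1ccc(C2=NCCN2)cc1)C(=O)COCCN(C)S(=O)(=O)c1ccccc1C#N` stands as the more stable of the two measured members in an ADME assay on microsomes from liver (Homo sapiens) for metabolic stability, with a stated time of 30 min, tested at 1 uM; on this read-out lower numbers stand for a less stable compound and higher numbers for a more stable compound: there compound 1 gives 87%, whereas compound 2 `COc1cc(C)c(S(=O)(=O)N(C)CCOCC(=O)N2CCN([C@@H]3CN4CCC3CC4)CC2)c(C)c1` gives 57%, a gap beyond the usual scatter. Compound 3 `CN(Cc1ccc(C2=NCCN2)cc1)C(=O)COCCN(C)S(=O)(=O)c1ccccc1C(F)(F)F` keeps the core of compound 1 and differs from it only by trifluoromethyl in place of cyano on an aromatic carbon. For the measured compounds named here, no measured step of this kind exists, so the expected change from compound 1 to compound 3 in this assay is a number 7 percentage points lower from compound 1 to compound 3 (within the scatter), a step within the scatter. Compound 3 is accordingly estimated at 80% in this assay, with a range from 60% to 95%.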

Compound 3, percent of the compound remaining: 50%
Compound 3: the middle estimate sits 30 percentage points above what was measured; measured number below the stated range.
By their numbers in this assay, from the lowest: compounds 3 and 2 (each within the scatter of the next); then compound 1.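

In this assay, trifluoromethyl in place of cyano on an aromatic carbon, ortho to a large group, gives a number 37 percentage points lower from compound 1 to compound 3 (beyond the scatter). Among the compounds shown here, this is the first single-place step, and it shows that stability on the core of compound 1 depends on the group at this position, with the nitrile ahead of trifluoromethyl. Nothing at hand accounts for the size of this step. Open, from the compounds shown here alone, is whether chlorine, an amine or a carboxylic acid at this position would keep the stability of compound 1. Also open, going by these compounds, is whether the same change would give a similar step on another core.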